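The source may hold more compounds than are shown below. What is called first, only, known or untested is meant among the compounds shown, and "the series" means these compounds.

Measured compounds:
compound 1, `COc1ccc(Cc2nnc3sc(-c4ccnc(F)c4)nn23)cc1OC`, 11.1%
compound 2, `COc1ccc(Cc2nnc3n2NC(c2ccco2)S3)cc1OC`, 12%
compound 3, `COc1ccc(Cl)c(-c2nnc3n2NC(c2cccn2C)S3)c1`, 14.1%

The three compounds were tested in a functional assay on the whole organism (strain Wistar Albino) for inhibition, with Rattus norvegicus as the target, read by paw edema, with a stated time of 1 h, at a dose of 20 mg/kg; a higher number here means more inhibition at the dose given (going by the name of the read-out), a lower number less inhibition. Compound 1 gives 11.1%, compound 2 gives 12%, and compound 3 gives 14.1%. All three numbers lie close together: the gap from compound 2 to compound 1 and the gap from compound 2 to compound 3 both fall within the usual scatter, so the three values cannot be set apart from one another and compound 2 stands in the same band as the other two.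

Compound 4, `COc1ccc(Cc2nnc3n2NC(c2cccn2C)S3)cc1OC`, is not yet measured. It differs from compound 2 in one place: 1-methyl-1H-pyrrol-2-yl in place of furan-2-yl on a saturated ring carbon. Compound 3 carries the same 1-methyl-1H-pyrrol-2-yl on the same saturated ring carbon, although its other ring differs, and it gives a value in the same band as compound 2 in this assay.

On these numbers alone, the step from compound 2 to compound 4 is expected to be none beyond the scatter, a number 1 percentage points higher from compound 2 to compound 4 (within the scatter). Compound 4 is therefore estimated at 13% in this assay, within a range from 6% to 22%.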

Compound 4, a percentage reported as inhibition, in the whole organism at one dose (the size of the read-out at that dose, not a potency): 13.4%
Compound 4: middle estimate off by 0.4 percentage points, on the low side; low and high end bracket the measured number.
By their numbers in this assay, from the lowest: compounds 1, 2, 4 and 3 (each within the scatter of the next).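

For the compounds shown here, the pair gives the first direct reading at this saturated ring carbon in this assay: with the rest of the molecule unchanged, 1-methyl-1H-pyrrol-2-yl in place of furan-2-yl gives a number 1.4 percentage points higher from compound 2 to compound 4 (within the scatter), so exchanging one of these five-membered aromatic rings for the other does not move the read-out beyond the scatter. The earlier compounds shown here could not show this, as compound 3 carries the same 1-methyl-1H-pyrrol-2-yl but also differs from compound 2 elsewhere, and no step between measured compounds could yet be read. Nothing given here offers an explanation for how this change behaves.

What an amine, a carboxylic acid or a longer chain on this saturated ring carbon would do to the read-out remains open, since the compounds shown offer only this one exchange at the position. On these data alone, it also remains open whether the same exchange would read alike on a different core, or whether any group at this position could lift the inhibition clear of the band in which all these compounds lie.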